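This account rests on a few compounds, and the source may have more. Where it says the series, first, only, none or still open, it means among the compounds named here.

Compound 1 `Nc1nc(-c2cccc(CO)c2)nc2sc(-c3ccccc3)nc12` is one of three compounds that share a core and differ only in the group placed between two ring nitrogen atoms. In a functional assay on CHO cells for antagonist activity at adenosine receptor A2b (Homo sapiens), read by cAMP accumulation, with a stated time of 10 min (on this read-out lower numbers stand for stronger inhibition and higher numbers for weaker inhibition), compound 1 gives > 30000 nM, which is a limit of the assay and not a number. Compound 2 `Nc1nc(-c2ccc(CO)cc2)nc2sc(-c3ccccc3)nc12` gives > 30000 nM in this assay, likewise a limit. Compound 3 `Nc1nc(-c2cccc(O)c2)nc2sc(-c3ccccc3)nc12` gives > 30000 nM in this assay, again a limit. Hence all three sit at the same point, as the limit of > 30000 nM in this assay, at which 3 of the 3 values shown sit, records, and none of the steps among them can be read: a step that the two limits leave unreadable from compound 1 to compound 2, a step that the two limits leave unreadable from compound 1 to compound 3 and a step that the two limits leave unreadable from compound 2 to compound 3 all stay unreadable.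

Compound 4 `Cc1ccc(-c2nc(N)c3nc(-c4ccccc4)sc3n2)o1` is not yet measured. It differs from compound 1 by 5-methylfuran-2-yl in place of 3-(hydroxymethyl)phenyl on an aromatic carbon. Among the measured compounds shown here, none of the measured steps concerns a five-membered ring at this place, and none of them has a readable size, so they give no direction for the step from compound 1 to compound 4. What can be said is that every aryl group tried so far at this place left the compound at the limit in this assay. The estimate for compound 4 therefore is wide: it is expected at about 8000 nM, within a range from 300 nM to 60000 nM, with a fair chance that the assay again reports only a limit; this corresponds to an expected at least 3.7-fold lower number from compound 1 to compound 4 (0.57 log units; beyond the scatter).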

Compound 4, half-maximal inhibitory concentration: > 30000 nM
Compound 4 was reported as a limit; the forecaster's own chance of this, stated with the estimate: 50%; middle value at least 3.7-fold (0.57 log units) from the limit.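

Compound 4 is also reported only as a limit, so none of the steps to it from compound 1, compound 2 and compound 3 can be read. The compounds shown leave open whether any group at this place on the shared core gives a measurable number in this assay, and how far such groups would differ.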